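Dimethylamino in place of bromo in compound 2

This account rests on a few compounds, and the source may have more. Where it says the series, first, only, none or still open, it means among the compounds named here.

In a functional assay on A549 cells (Homo sapiens) for antiproliferative activity, read by MTT assay, with a stated time of 48 h (a higher number here means a weaker inhibitor, a lower number a stronger inhibitor), compound 1 `Cc1cc(Br)c2nc(-c3nnc(-c4ccc(Cl)cc4)o3)cn2c1` gives 43500 nM and compound 2 `Cc1cc(Br)c2nc(-c3nnc(-c4ccc(Br)cc4)o3)cn2c1` gives 23400 nM as its reading. Among the compounds with values here, compound 2 thus stands within the scatter of compound 1, the only other measured compound, and the two cannot be ranked. The next compound, compound 3 `Cc1cc(Br)c2nc(-c3nnc(-c4ccc(N(C)C)cc4)o3)cn2c1`, carries dimethylamino in place of bromo on an aromatic carbon, para to a large group (dimethylamino in place of bromo on an aromatic carbon). Within the data shown here, one measured step bears on this place: bromo in place of chloro (a 1.9-fold lower number from compound 1 to compound 2 (0.27 log units; within the scatter)), which stays within the scatter. Among the measured compounds shown here, that step exchanges one halogen for another, and no measured compound carries anything other than a halogen there, so it offers only weak guidance for the new group. No step beyond the scatter is therefore expected in this assay in either direction, although the uncertainty remains wide. The estimated change is small (a 1.2-fold lower number from compound 2 to compound 3 (0.07 log units; within the scatter)). Compound 3 is expected to read 20000 nM with an estimated range of 6000 nM to 70000 nM as its likely span.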

Compound 3, half-maximal inhibitory concentration: 10800 nM
Estimate against measurement, compound 3: 1.9-fold (0.27 log units) above; low and high end bracket the measured number.
By their numbers in this assay, from the lowest: compound 3; then compounds 2 and 1 (each within the scatter of the next).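

The halogens alone gave no readable difference at this place, para to a large group, but a group of another kind does: in this assay, dimethylamino in place of bromo gives a step beyond the scatter (a 2.2-fold lower number from compound 2 to compound 3 (0.34 log units; beyond the scatter)), and dimethylamino in place of chloro gives a somewhat larger one (a 4.0-fold lower number from compound 1 to compound 3 (0.61 log units; beyond the scatter)). Both steps are modest, yet they make compound 3 the strongest inhibitor of the three and show that this position on the six-membered aromatic ring of carbon only accepts a nitrogen-bearing group of three heavy atoms, with a hydrogen-bond acceptor counted where the halogens had none, without any loss of activity. No measurement at hand explains why the reading falls with this change.

With a single non-halogen group, the compounds shown cannot separate the part played by the nitrogen from that of the larger size of the group. On these data alone, whether a smaller amine, a ring amine such as morpholine, or a methoxy group at the same place would go further in the same direction remains open.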